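The source may hold more compounds than are shown below. What is called first, only, known or untested is meant among the compounds shown, and "the series" means these compounds.

Compounds measured in a functional assay on U-251 cells (Homo sapiens) for cytotoxicity, read by sulforhodamine B assay, with a stated time of 48 h, tested at 100 uM; a higher number here means a weaker effect of the compound at the concentration tested, a lower number a stronger effect:
compound 1 `COc1cc(-c2cc(/C=C/C(=O)c3ccc(N)cc3)[nH]n2)cc(OC)c1OC`, -98%
compound 2 `COc1ccc(-c2cc(/C=C/C(=O)c3ccc(N)cc3)[nH]n2)cc1`, -100%
compound 3 `COc1ccc(C(=O)/C=C/c2cc(-c3cc(OC)c(OC)c(OC)c3)n[nH]2)cc1`, -25%

Compound 1 stands second highest of the three numbers in this assay. Its nearest neighbour is compound 2, whose value lies within the scatter of that of compound 1, so the two cannot be told apart. Going by the values given here, compound 3 is the furthest away: the step of a number 73 percentage points higher from compound 1 to compound 3 (beyond the scatter) is large and well beyond the scatter, the sole structural change there being methoxy in place of amino on an aromatic carbon.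

Compound 4 `COc1ccc(C(=O)/C=C/c2cc(-c3cc(OC)c(OC)c(OC)c3)n[nH]2)cc1OC` has not yet been measured in this assay. It differs from compound 1 as follows: 3,4-dimethoxyphenyl in place of 4-aminophenyl on a carbonyl carbon. Among the compounds with values here, the only measured step that bears on this change is the one from compound 1 to compound 3, where the amino group on the aromatic ring was also given up, and it was large. Within the data shown here, compound 4 likewise loses the amino group, while carrying an added methoxy that no measured pair addresses. A large upward step in this assay is therefore expected, a number 68 percentage points higher from compound 1 to compound 4 (beyond the scatter). For compound 4 the value in this assay is estimated at -30%, between -70% and 5%.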

Compound 4, a percentage reported as activity, at one concentration (the size of the read-out at that concentration, not a potency): -99%
Compound 4: the middle estimate sits 69 percentage points above what was measured; measured number below the stated range.
By their numbers in this assay, from the lowest: compounds 2, 4 and 1 (each within the scatter of the next); then compound 3.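

In this assay the step of a number 1 percentage points lower from compound 1 to compound 4 (within the scatter) shows that 4-aminophenyl on this carbonyl carbon can give way to 3,4-dimethoxyphenyl with no change that can be told from the scatter, so the amino group is not needed for the effect in these compounds. The large step of a number 74 percentage points lower from compound 3 to compound 4 (beyond the scatter) comes from the added methoxy alone, so the loss of amino does not by itself set the number of compound 3 . What lies behind this difference cannot be said, as no supporting evidence bears on it.

On these data alone, whether a 4-hydroxyphenyl or a 4-(dimethylamino)phenyl on the carbonyl carbon would go with compound 1 or with compound 3 stays open. So does whether the added methoxy would have the same effect with an ethoxy group in its place.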